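This account rests on a few compounds, and the source may have more. Where it says the series, first, only, none or still open, it means among the compounds named here.

Compound 1 is `COc1cc2ncnc(Nc3cc(-c4ccc(F)cc4)[nH]n3)c2cc1OC`. In a functional assay on DU-145 cells (Homo sapiens) for cytotoxicity, read by MTT assay (on this read-out higher numbers stand for weaker inhibition and lower numbers for stronger inhibition), compound 1 gives < 100000 nM, which is a limit of the assay and not a number.

Compound 2 is `COc1cc2ncnc(Nc3cc(-c4ccc(Cl)cc4)[nH]n3)c2cc1OC`. In this assay compound 2 gives < 100000 nM, again a limit of the assay rather than a number.

For the measured compounds named here, compound 2 therefore stands only at a limit in this assay, and the one other value shown sits at the same limit (the limit of < 100000 nM in this assay, at which 2 of the 2 values shown sit). Compound 3 is `COc1ccc(-c2cc(Nc3ncnc4cc(OC)c(OC)cc34)n[nH]2)cc1`; it differs from compound 2 by methoxy in place of chloro on an aromatic carbon. Going by the values given here, the only measured step, a step that the two limits leave unreadable from compound 1 to compound 2, cannot be read in size, as both of its ends are limits, so it gives neither direction nor magnitude. Among the compounds with values here, no measured step touches a methoxy in place of chloro. The expected step that the limit leaves unreadable from compound 2 to compound 3 is accordingly set near zero, with a wide range. For compound 3 in this assay the estimate is 40000 nM, expected to fall between 5000 nM and 150000 nM, most likely reported again only as a limit.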

Compound 3, half-maximal inhibitory concentration: < 100000 nM
Compound 3 was reported as a limit (the forecaster's own chance of this, stated with the estimate: 70%); the middle value lies beyond the limit too.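

For the compounds shown here, no step between compound 1, compound 2 and compound 3 can be read in this assay, because each value is a limit and not a number: the limit of < 100000 nM in this assay, at which 3 of the 3 values shown sit. From the compounds shown here alone, whether fluoro, chloro and methoxy differ in their effect on cytotoxicity, and by how much, stays open.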